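A few compounds are considered here, and "the series" means these few. Any claim that something is new, unique, unknown or untested is made for them only; others in the source may bear on it.

Compound 1 `COC(=O)c1cccc(-c2cc(C(=O)Nc3ccncc3)ccc2CN)c1` was measured in an ADME assay on a cell-free system (plasma, Homo sapiens) for metabolic stability, read by LC-MS (on this read-out higher numbers stand for a longer-lived compound and lower numbers for a shorter-lived compound), where compound 1 gives 1.52 h. Going by the values given here, of the two compounds measured so far, compound 1 has the higher number. The other one, compound 2 `CC(C)OCCOC(=O)c1cccc(-c2cc(C(=O)Nc3ccncc3F)ccc2CN)c1`, differs from it in several places, and in this assay compound 2 gives 0.1 h, a gap beyond the usual scatter.

Compound 3 `CCCOC(=O)c1cccc(-c2cc(C(=O)Nc3ccncc3)ccc2CN)c1` has not been measured yet. Among the compounds with values here, its only difference from compound 1 is ethyl in place of hydrogen on a saturated chain carbon bound to an oxygen next to a carbonyl group. Within the data shown here, no single-point step is available to guide this. The change is expected to produce no shift beyond the scatter, so the step of a 1.3-fold lower number from compound 1 to compound 3 (0.10 log units; within the scatter) is an estimate of near-constancy. Compound 3 is therefore expected at 1.2 h, between 0.4 h and 3.5 h.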

Compound 3, half-life: 0.3 h
Estimate against measurement, compound 3: 4.0-fold (0.60 log units) above, and the stated range ends above it.
By their numbers in this assay, from the lowest: compound 2; then compound 3; then compound 1.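

In this assay, going by these compounds alone, this is the first change at this position that can be read on its own: going from methoxycarbonyl to propoxycarbonyl gives a 5.1-fold lower number from compound 1 to compound 3 (0.70 log units; beyond the scatter). Adding ethyl on the saturated chain carbon bound to an oxygen next to a carbonyl group is therefore enough to shorten the half-life, with the rest of compound 1 unchanged. Nothing at hand explains this drop. With only methyl and propyl to compare here, no trend with chain length can be drawn. From the compounds shown here alone, how a longer chain such as butyl, or a carboxylic acid in place of the methoxycarbonyl, would behave remains open.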